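This account rests on a few compounds, and the source may have more. Where it says the series, first, only, none or still open, it means among the compounds named here.

Working notes on the aryl tail of the shared core. Compound 1 `CC(C)C[C@H](N)c1cc(C(F)(F)F)ccc1N1CCN(C(=O)CCc2ccc(O)cc2)CC1` carries a 4-hydroxyphenyl on the chain and in an assay on HEK293 cells for displacement of a labelled ligand from Melanocortin receptor 4 (Homo sapiens) (on this read-out higher numbers stand for weaker inhibition and lower numbers for stronger inhibition), gives only a limit, > 10000 nM. Compound 2 `CC(C)C[C@H](N)c1cc(C(F)(F)F)ccc1N1CCN(C(=O)CCc2ccc(S(C)(=O)=O)cc2)CC1` gives 4900 nM, and compound 3 `CC(C)C[C@H](N)c1cc(C(F)(F)F)ccc1N1CCN(C(=O)CCc2c(Cl)cccc2Cl)CC1` gives 2600 nM. The step of an at least 2.0-fold lower number from compound 1 to compound 2 (0.30 log units; that floor lies within the scatter) rests on the limit (the limit of > 10000 nM in this assay, at which 1 of the 3 values shown sits), and the step of an at least 3.8-fold lower number from compound 1 to compound 3 (0.58 log units; beyond the scatter) likewise; the step of a 1.9-fold lower number from compound 2 to compound 3 (0.28 log units; within the scatter) is within the scatter, so compound 3 and compound 2 cannot be ordered against each other, and compound 3 is separated only from the limit of compound 1.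

Compound 4 `CC(C)C[C@H](N)c1cc(C(F)(F)F)ccc1N1CCN(C(=O)CCc2c[nH]c3ccccc23)CC1` differs from compound 3 by 1H-indol-3-yl in place of 2,6-dichlorophenyl on a saturated chain carbon, two bonds along the chain from a carbonyl carbon. For the measured compounds named here, no measured step exchanges one aromatic tail that lacks a donor for another aromatic tail that carries one, so none of the three steps speaks directly to it; the two steps from compound 1 show only that a 4-hydroxyphenyl tail sits at the limit. The step of a 1.3-fold higher number from compound 3 to compound 4 (0.13 log units; within the scatter) is therefore expected to fall within the scatter. Compound 4 is estimated at 3500 nM, within 900 nM to 14000 nM.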

Compound 4, inhibition constant: 640 nM
For compound 4 the middle estimate is 5.5-fold (0.74 log units) above the measured one, outside the stated range (below it).
By their numbers in this assay, from the lowest: compound 4; then compounds 3 and 2 (each within the scatter of the next). At a limit, above all of these: compound 1.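

In this assay, 1H-indol-3-yl is the only tail shown at this place that separates by a measured number from both other measured tails: a 4.1-fold lower number from compound 3 to compound 4 (0.61 log units; beyond the scatter) and a 7.7-fold lower number from compound 2 to compound 4 (0.88 log units; beyond the scatter), whereas 2,6-dichlorophenyl and 4-(methylsulfonyl)phenyl could not be ordered. The entering group carries a hydrogen-bond donor and a second aromatic ring, but a donor alone does not go with a low number here, and compound 1, with its hydroxy group, goes against that reading. Compound 1 remains a limit and not a number, so an at least 15-fold lower number from compound 1 to compound 4 (1.19 log units; beyond the scatter) gives only a floor: the limit of > 10000 nM in this assay, at which 1 of the 4 values shown sits.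

The compounds shown leave open whether the lower number goes with the indole hydrogen or with the second ring, which a 1-methyl-1H-indol-3-yl or a naphthalen-1-yl tail would separate. As far as these compounds go, a longer chain to the 1H-indol-3-yl also remains open.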